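The source may report more compounds than this note shows. Statements on the series, on what has been measured and on what is new or still open speak of the compounds shown alone.

Measured compounds:
- compound 1 `C=CCOc1cc(OC)c(C(=O)/C=C/c2ccc([N+](=O)[O-])cc2)c(OCC=C)c1`: 12600 nM
- compound 2 `C=CCOc1cc(OC)c(C(=O)/C=C/c2ccccc2)c(OCC=C)c1`: 17100 nM
- compound 3 `C=CCOc1cc(OC)c(C(=O)/C=C/c2cc(OC)c(OC)c(OC)c2)c(OCC=C)c1`: 40900 nM

In an ADME assay on Vero cells (Chlorocebus sabaeus) for cytotoxicity, read by MTT assay (on this read-out lower numbers stand for stronger inhibition and higher numbers for weaker inhibition), compound 2 gives 17100 nM and stands second highest of the three numbers. Its nearest neighbour is compound 1, which in this assay gives 12600 nM; the two values lie within the scatter of each other, as the step of a 1.4-fold higher number from compound 1 to compound 2 (0.13 log units; within the scatter) shows. The furthest is compound 3, which in this assay gives 40900 nM, a higher number that lies beyond the scatter.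

Compound 4 `C=CCOc1cc(OC)c(C(=O)/C=C/c2cccc(OC)c2)c(OCC=C)c1` is not yet measured. It differs from compound 2 by methoxy in place of hydrogen on an aromatic carbon.

For the measured compounds named here, only one measured step changes a single group on the same ring, a 1.4-fold higher number from compound 1 to compound 2 (0.13 log units; within the scatter), and it stays within the scatter. Going by the values given here, compound 3 carries three methoxy groups on that ring and shows a higher number than compound 2, but no single step separates the two, so the weight of one methoxy alone cannot be read from it. On this basis a single methoxy is expected to move the number little, with a small lean toward a higher value, likely within the scatter; the expected step is a 1.2-fold higher number from compound 2 to compound 4 (0.09 log units; within the scatter).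

Compound 4 is expected to give about 21000 nM in this assay, with a range from 11000 nM to 40000 nM.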

Compound 4, half-maximal inhibitory concentration: 142000 nM
For compound 4 the middle estimate is 6.8-fold (0.83 log units) below the measured one, and the stated range ends below it.
By their numbers in this assay, from the lowest: compounds 1 and 2 (each within the scatter of the next); then compound 3; then compound 4.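

In this assay, for the compounds shown here, this place on the ring, meta to a large group, proves far more sensitive than the earlier compounds suggested: methoxy in place of hydrogen gives an 8.3-fold higher number from compound 2 to compound 4 (0.92 log units; beyond the scatter) and lies clearly beyond the scatter, whereas the only earlier single change on this ring, a 1.4-fold higher number from compound 1 to compound 2 (0.13 log units; within the scatter) and so within the scatter, gave no sign of such a move. The exchange of 4-nitrophenyl for 3-methoxyphenyl gives an 11-fold higher number from compound 1 to compound 4 (1.05 log units; beyond the scatter) and shows that, in this series, the substitution on this ring can shift the number toward weaker inhibition by a wide margin. Nothing available accounts for the size of these steps.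

Open, on these data alone, is whether the step belongs to methoxy itself or would also appear with another group at this same place, such as an amine, a hydroxyl or a longer chain like ethoxy. Also open, as far as these compounds go, is how methoxy at this place would behave with a nitro group kept on the same ring, since the two groups are seen here only as an exchange of one ring for the other.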